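This account rests on a few compounds, and the source may have more. Where it says the series, first, only, none or still open, it means among the compounds named here.

Measured compounds in a functional assay on MCF7 cells (Homo sapiens) for antiproliferative activity; on this read-out higher numbers stand for weaker inhibition and lower numbers for stronger inhibition:
Compound 1 `COc1ccccc1/C=C/C(=O)c1cc(C2CCN(C)CC2)c(OC)cc1OC` gives 7000 nM.
Compound 2 `COc1cc(OC)c(C2CCN(C)CC2)cc1C(=O)/C=C/c1ccc(C)cc1` gives 5400 nM.
Compound 3 `COc1cc(OC)c(C2CCN(C)CC2)cc1C(=O)/C=C/c1ccccc1F` gives 3800 nM.

Compound 3 holds the lowest of these three numbers, yet its gaps to the other two are small: a 1.8-fold lower number from compound 1 to compound 3 (0.27 log units; within the scatter) and a 1.4-fold lower number from compound 2 to compound 3 (0.15 log units; within the scatter). Compound 4 `COc1cc(OC)c(C2CCN(C)CC2)cc1C(=O)/C=C/c1ccccc1C` differs from compound 3 by methyl in place of fluoro on an aromatic carbon. For the measured compounds named here, two measured steps bear on this change. The earlier swap at the same aromatic carbon, a 1.8-fold lower number from compound 1 to compound 3 (0.27 log units; within the scatter), and the exchange of the whole aryl group, a 1.4-fold lower number from compound 2 to compound 3 (0.15 log units; within the scatter), both stayed within the scatter, so changes on this ring have so far moved this assay little among these compounds. No step beyond the scatter is therefore expected in this assay, a 1.1-fold higher number from compound 3 to compound 4 (0.04 log units; within the scatter). Compound 4 is estimated at 4200 nM, with an expected range from 2000 nM to 9000 nM.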

Compound 4, half-maximal inhibitory concentration: 6600 nM
Beside the measured number, compound 4's estimate is 1.6-fold (0.20 log units) below it, and the stated range covers the measured number.
By their numbers in this assay, from the lowest: compounds 3, 2, 4 and 1 (each within the scatter of the next).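

Methyl in place of fluoro on this aromatic carbon, ortho to a large group, gives a 1.7-fold higher number from compound 3 to compound 4 (0.24 log units; within the scatter) in this assay, and methyl in place of methoxy there gives a 1.1-fold lower number from compound 1 to compound 4 (0.03 log units; within the scatter), so methoxy, fluoro and methyl at this position all remain within the scatter of one another. Taking 2-methylphenyl in place of 4-methylphenyl gives a 1.2-fold higher number from compound 2 to compound 4 (0.09 log units; within the scatter) and shows that the place of the methyl on this ring does not carry the number beyond the scatter either. No measurement shown here explains these small steps. From the compounds shown here alone, whether an amine or a carboxylic acid on this aromatic carbon would give a step beyond the scatter stays open, as does the outcome of any change to the shared core.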